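From Bromophenyl to Methylphenyl: Predicting Compound 4

The compounds below may be only part of what the source reports. "The series", "measured", "known", "first", "only" and "open" are said of these compounds alone.

Compound 1, `Oc1ccccc1/C=N/c1nnc(SCc2nnc(-c3ccc(F)cc3)o2)s1`, gives 15600 nM in a functional assay on MCF7 cells (Homo sapiens) for inhibition, read by CCK-8 assay; a higher number here means a weaker inhibitor, a lower number a stronger inhibitor.
Compound 2, `Oc1ccccc1/C=N/c1nnc(SCc2nnc(-c3ccc(Cl)cc3)o2)s1`, gives 7550 nM.
Compound 3, `Oc1ccccc1/C=N/c1nnc(SCc2nnc(-c3ccccc3Br)o2)s1`, gives 9140 nM.

Compound 3 stands second highest of the three numbers. Its separation from compound 2, a 1.2-fold higher number from compound 2 to compound 3 (0.08 log units; within the scatter), and from compound 1, a 1.7-fold lower number from compound 1 to compound 3 (0.23 log units; within the scatter), both lie within the scatter, so these three compounds cannot be ordered with confidence. Compound 4, `Cc1ccc(-c2nnc(CSc3nnc(/N=C/c4ccccc4O)s3)o2)cc1`, differs from compound 3 in one place: 4-methylphenyl in place of 2-bromophenyl on an aromatic carbon. The measured steps all vary the same phenyl group. Only a 2.1-fold lower number from compound 1 to compound 2 (0.32 log units; beyond the scatter) was beyond the scatter, and it was modest. Going by the values given here, no measured step involves a methylphenyl, so the expectation rests on the small range seen so far: compound 4 is expected to show a 1.0-fold lower number from compound 3 to compound 4 (0.01 log units; within the scatter), no step beyond the scatter. Compound 4 is estimated at 9000 nM, within 3500 nM to 25000 nM.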

Compound 4, half-maximal inhibitory concentration: 8750 nM
Beside the measured number, compound 4's estimate is 1.0-fold (0.01 log units) above it; measured number inside the range.
By their numbers in this assay, from the lowest: compounds 2, 4, 3 and 1 (each within the scatter of the next, the first and the last beyond it).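

A phenyl group carrying no halogen, 4-methylphenyl, falls in the same range as the halogen-bearing groups on this aromatic carbon. Its steps from 2-bromophenyl (a 1.0-fold lower number from compound 3 to compound 4 (0.02 log units; within the scatter)), from the chloro group (a 1.2-fold higher number from compound 2 to compound 4 (0.06 log units; within the scatter)) and from the fluoro group (a 1.8-fold lower number from compound 1 to compound 4 (0.25 log units; within the scatter)) all lie within the scatter, so among these compounds a halogen is not required for a number in this range in this assay. No available evidence explains this result.

Still open, going by these compounds, is whether an amine, a carboxylic acid or a longer chain on this phenyl ring would give a step beyond the scatter.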